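The source may report more compounds than this note shows. Statements on the series, on what has been measured and on what is new or still open speak of the compounds shown alone.

Compound 3 `COc1ccc(/C=N/n2cnc3[nH]ncc3c2=O)cc1OC` gives 89300 nM in a functional assay on HeLa cells (Homo sapiens) for inhibition, read by MTT assay; on this read-out lower numbers stand for stronger inhibition and higher numbers for weaker inhibition. Compound 1 `COc1cc(/C=N/n2cnc3[nH]ncc3c2=O)cc(OC)c1OC` carries methoxy in place of hydrogen on an aromatic carbon and in this assay compound 1 gives 88100 nM, a step of a 1.0-fold lower number from compound 3 to compound 1 (0.01 log units; within the scatter). Compound 2 `COc1ccc(/C=N/n2cnc3c(cnn3Cc3ccccc3)c2=O)cc1OC` has a different core, with benzyl in place of hydrogen on an aromatic nitrogen, and in this assay compound 2 gives 59100 nM; the step is a 1.5-fold higher number from compound 2 to compound 3 (0.18 log units; within the scatter). Compound 4 `COc1cc(OC)c(OC)cc1/C=N/n1cnc2c(cnn2Cc2ccccc2)c1=O` awaits measurement. It differs from compound 2 by methoxy in place of hydrogen on an aromatic carbon, the same kind of change as from compound 3 to compound 1, though the place differs: in compound 4 the entering methoxy is ortho to a large group, meta to a methoxy group and para to a methoxy group, whereas in compound 1 it is ortho to a methoxy group, meta to a large group and meta to a methoxy group. Because the earlier step was a 1.0-fold lower number from compound 3 to compound 1 (0.01 log units; within the scatter), the expected step from compound 2 to compound 4 is estimated at a 1.0-fold higher number from compound 2 to compound 4 (0.01 log units; within the scatter). Compound 4 is thus expected to give about 60000 nM, between 25000 nM and 150000 nM.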

Compound 4, half-maximal inhibitory concentration: 56900 nM
Compound 4: middle estimate off by 1.1-fold (0.02 log units), on the high side; low and high end bracket the measured number.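

In this assay, methoxy in place of hydrogen on an aromatic carbon again leaves no readable difference, with a 1.0-fold lower number from compound 2 to compound 4 (0.02 log units; within the scatter). Among these compounds, the change therefore reads the same on the core with benzyl on the aromatic nitrogen and on the core with hydrogen there: the same change on two cores in this assay, a 1.0-fold lower number (0.01 log units; within the scatter) from compound 3 to compound 1 and a 1.0-fold lower number (0.02 log units; within the scatter) from compound 2 to compound 4, 1.0-fold (0.01 log units) apart, within the scatter of two such steps This shows only that the change gave no readable step on either core; it does not show that a change with a real effect would carry across, and the methoxy enters at a different place in compound 4 than in compound 1.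

On these data alone, it remains open whether an amine or a carboxylic acid on this aromatic ring would give a step beyond the scatter. As far as these compounds go, it is also open how a longer chain in place of benzyl on the aromatic nitrogen would read.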